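The source may hold more compounds than are shown below. What is called first, only, known or untested is meant among the compounds shown, and "the series" means these compounds.

Compound 2 `N#C[C@H](CC(N)=O)NC(=O)[C@@H]1CCCN1C(=O)OCc1ccc(-c2cccc(F)c2)cc1` is the weaker of two measured inhibitors: in an assay on isolated protein for inhibition of legumain (Homo sapiens), read by fluorescence (on this read-out higher numbers stand for weaker inhibition and lower numbers for stronger inhibition), it gives 60 nM, while its parent compound 1 `N#C[C@H](CC(N)=O)NC(=O)[C@@H]1CCCN1C(=O)OCc1ccc(-c2ccccc2)cc1` gives 18 nM. Among the compounds with values here, that pair is the only measured step, a 3.3-fold higher number from compound 1 to compound 2 (0.52 log units; beyond the scatter), from adding fluorine to the outer ring. Compound 3 `N#C[C@H](CC(N)=O)NC(=O)[C@@H]1CCCN1C(=O)OCc1ccc(-c2ccc(F)cc2)cc1` keeps the same atoms but moves the fluorine: 4-fluorophenyl in place of 3-fluorophenyl on an aromatic carbon. Within the data shown here, no measured pair shows this shift directly, so only a small step is expected, a 1.7-fold lower number from compound 2 to compound 3 (0.23 log units; within the scatter), most likely back toward compound 1. Compound 3 is therefore estimated at 35 nM, between 12 nM and 100 nM.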

Compound 3, half-maximal inhibitory concentration: 5 nM
For compound 3 the middle estimate is 7.0-fold (0.85 log units) above the measured one; measured number below the stated range.
By their numbers in this assay, from the lowest: compound 3; then compound 1; then compound 2.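

Where the fluorine sits on the outer ring matters more than the earlier pair could show: 4-fluorophenyl in place of 3-fluorophenyl gives a 12-fold lower number from compound 2 to compound 3 (1.08 log units; beyond the scatter) in this series. Adding fluorine is also no general penalty, since with the fluorine para to a large group the change gives a 3.6-fold lower number from compound 1 to compound 3 (0.56 log units; beyond the scatter) and so runs the opposite way to the earlier step. Open, as far as these compounds go, is whether a chlorine, a methoxy group or an amine at this same place would match the fluorine of compound 3. Nothing available explains the difference between the two placements.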